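Oxadiazole in Place of Pyrimidine on the Piperidine Nitrogen

A few compounds are considered here, and "the series" means these few. Any claim that something is new, unique, unknown or untested is made for them only; others in the source may bear on it.

compound 1 `CCc1cnc(N2CCC(CCCNc3ccc4c(c3)C(=O)CC4)CC2)nc1`: 51 nM
compound 2 `CC(C)(C)OC(=O)N1CCC(CCCNc2ccc3c(c2)C(=O)CO3)CC1`: 88 nM
compound 3 `COc1cnc(N2CCC(CCCNc3ccc4c(c3)OCC4=O)CC2)nc1`: 115 nM

Of the compounds shown here, three have been measured in a functional assay on CHO-K1 cells for agonist activity at Glucose-dependent insulinotropic receptor (Homo sapiens), read by HTRF and cAMP accumulation, with a stated time of 30 min; a lower number here means that less compound is needed, a higher number that more compound is needed for the effect. Compound 3 gives the highest of the three numbers. Its nearest neighbour is compound 2, whose number is lower by an amount that lies within the scatter, so no order can be read between these two. Compound 1 stands furthest away, with a number lower by more than the scatter. Going by the values given here, no pair of measured compounds differs in only one place, so the size of any single change cannot be taken from these three.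

Compound 4 `CC(C)c1nc(N2CCC(CCCNc3ccc4c(c3)OCC4=O)CC2)no1` has not yet been measured. It differs from compound 3 in one respect: 5-isopropyl-1,2,4-oxadiazol-3-yl in place of 5-methoxypyrimidin-2-yl on an amine nitrogen in a ring. Compound 1 with 51 nM, compound 2 with 88 nM and compound 3 with 115 nM carry three different groups on that ring nitrogen and still fall within a modest span, which suggests that this position tolerates change without large swings. In this assay compound 4 is therefore expected to move toward a lower number, by a small amount that may well stay within the scatter. This means an expected step of a 1.8-fold lower number from compound 3 to compound 4 (0.25 log units; within the scatter). Compound 4 is estimated at 65 nM, with a range from 20 nM to 200 nM.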

Compound 4, half-maximal effective concentration: 161 nM
For compound 4 the middle estimate is 2.5-fold (0.39 log units) below the measured one; the range from low to high includes it.
By their numbers in this assay, from the lowest: compounds 1, 2, 3 and 4 (each within the scatter of the next, the first and the last beyond it).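

In this assay, 5-isopropyl-1,2,4-oxadiazol-3-yl in place of 5-methoxypyrimidin-2-yl on an amine nitrogen in a ring gives a 1.4-fold higher number from compound 3 to compound 4 (0.15 log units; within the scatter). Going by these compounds alone, this is the first direct reading of a single change at this position, which the earlier compounds could only hint at, since they differ from one another in more than one place. It shows that a five-membered aromatic ring with 3 hetero atoms can stand in for a six-membered aromatic ring with 2 hetero atoms, at the same count of heavy atoms, without a difference that this assay can separate from the scatter, though nothing measured here bears on why the two groups read alike.

Going by these compounds, one exchange between two aromatic rings says little about the position as a whole, and it remains open whether the same holds for a group of another kind on that nitrogen, such as an acetyl group, a carboxylic acid or a longer alkyl chain. Also open, on these data alone, is whether a different substituent on the oxadiazole, such as a cyclopropyl or a tert-butyl group in place of the isopropyl, would give a step beyond the scatter.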